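A Chloro-Methylbenzyl Amide Replaces a Hydroxyphenoxy Group

This account rests on a few compounds, and the source may have more. Where it says the series, first, only, none or still open, it means among the compounds named here.

Measured so far in an assay on HEK293 cells for displacement of a labelled ligand from Melanocortin receptor 4 (Homo sapiens); on this read-out lower numbers stand for stronger inhibition and higher numbers for weaker inhibition:
- compound 1, `CC(C)C[C@H](N)c1cc(F)ccc1N1CCN(C(=O)C(C)Cc2ccc(Cl)cc2)CC1`, for which compound 1 gives 390 nM
- compound 2, `CC(C)C[C@H](N)c1cc(C(F)(F)F)ccc1N1CCN(C(=O)COc2ccc(O)cc2)CC1`, for which compound 2 gives 4600 nM

Compound 2 has the highest number of the two, so it is the weaker binder; its nearest neighbour is compound 1, whose number lies beyond the scatter below it. Compound 3, `Cc1cc(Cl)ccc1CC(C)C(=O)N1CCN(c2ccc(C(F)(F)F)cc2[C@@H](N)CC(C)C)CC1`, has not yet been measured in this assay. It differs from compound 2 in one place: 1-(4-chloro-2-methylbenzyl)ethyl in place of (4-hydroxyphenoxy)methyl on a carbonyl carbon. The group that enters has no hydrogen-bond donor or acceptor, whereas the group that leaves has both. The group entering compound 3 is close in make-up to the corresponding part of compound 1, and compound 1 gives 390 nM in this assay. Compound 3 is therefore expected to move toward that lower number, with an expected step of a 9.2-fold lower number from compound 2 to compound 3 (0.96 log units; beyond the scatter), beyond the scatter. Compound 3 is estimated at 500 nM, within a range from 150 nM to 2000 nM.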

Compound 3, inhibition constant: 38 nM
Beside the measured number, compound 3's estimate is 13-fold (1.12 log units) above it; measured number below the stated range.
By their numbers in this assay, from the lowest: compound 3; then compound 1; then compound 2.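

Because compound 2 and compound 3 differ in one place only, they isolate the effect of the group on the carbonyl carbon, which compound 1 and compound 2 could not do, as they differ in more than one place. In this assay, 1-(4-chloro-2-methylbenzyl)ethyl in place of (4-hydroxyphenoxy)methyl gives a 120-fold lower number from compound 2 to compound 3 (2.08 log units; beyond the scatter), so this position has a strong influence on the read-out. Both groups hold one six-membered aromatic ring, and the entering group, with 0 hydrogen-bond donors and 0 hydrogen-bond acceptors, shows that neither is required for a low number here; no measurement given explains the step.

The swap changes several features at once, so the chlorine, the methyl and the loss of the oxygens cannot be told apart. From the compounds shown here alone, how an amine or a carboxylic acid at this place would behave also stays open.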